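A few compounds are considered here, and "the series" means these few. Any claim that something is new, unique, unknown or untested is made for them only; others in the source may bear on it.

Measured compounds in an ADME assay on MDA-MB-435 cells (Homo sapiens) for cytotoxicity (a higher number here means that more compound is tolerated, a lower number that less compound is tolerated), all at the limit of the assay:
compound 1 `Cc1ccc(-n2c(SCC(=O)NNC(=O)c3ccccc3O)nnc2-c2ccccc2O)cc1` — > 20000 nM
compound 2 `O=C(CSc1nnc(Cc2ccccc2)n1-c1cccc(Cl)c1)NNC(=O)c1ccccc1O` — > 20000 nM
compound 3 `COc1ccc(-n2c(Cc3ccccc3)nnc2SCC(=O)NNC(=O)c2ccccc2O)cc1` — > 20000 nM

Compound 3 thus gives only a limit in this assay, not a number. Its two companions stand at the same limit, so none of the three can be set above or below another. For the measured compounds named here, the one step that joins two of them, a step that the two limits leave unreadable from compound 2 to compound 3, cannot be read for the same reason: both ends are limits, and the step's size stays hidden. What the three values do show is captured in one observation: the limit of > 20000 nM in this assay, at which 3 of the 3 values shown sit.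

Compound 4 `O=C(CSc1nnc(Cc2ccccc2)n1C1CCCCC1)NNC(=O)c1ccccc1O` is not yet measured. It differs from compound 3 in one place: cyclohexyl in place of 4-methoxyphenyl on an aromatic nitrogen. Going by the values given here, no measured step among the three compounds tracks this change, since the only step on record, the one from compound 2 to compound 3, swaps one aromatic group for another at that nitrogen and is unreadable anyway. Among the compounds with values here, the only guide is that every compound seen so far sits at the limit, as recorded in the limit of > 20000 nM in this assay, at which 3 of the 3 values shown sit.

Given that, compound 4 is expected to tolerate a comparably high concentration, estimated at 25000 nM with a range of 10000 nM to 60000 nM, and the step from compound 3 to compound 4 is expected to be a step that the limit leaves unreadable from compound 3 to compound 4, most likely again reported as a limit rather than a number.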

Compound 4, half-maximal cytotoxic concentration: > 20000 nM
Compound 4 ended at the assay's limit; the forecaster's own chance of this, stated with the estimate: 85%; the middle value lies beyond the limit too.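

In this assay compound 4 gives > 20000 nM, which is a limit and not a number. The steps from compound 2 and compound 3 to compound 4 cannot be read, because both ends of each are limits: the limit of > 20000 nM in this assay, at which 4 of the 4 values shown sit. The compounds shown leave open whether they differ at all in how much is tolerated, and at what concentration any of them becomes toxic to these cells.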